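A few compounds are considered here, and "the series" means these few. Any claim that something is new, unique, unknown or untested is made for them only; others in the source may bear on it.

Compound 1, `CCCCNC(=O)c1cc(NC(=O)c2cnc(Cl)nc2C(F)(F)F)cc(C(F)(F)F)c1`: in an assay on Jurkat cells for inhibition of nuclear factor NF-kappa-B p105 subunit (Homo sapiens) (a lower number here means a stronger inhibitor, a higher number a weaker inhibitor), compound 1 gives > 10000 nM, which is a limit of the assay rather than a number (the limit of > 10000 nM in this assay, at which 1 of the 3 values shown sits).
Compound 2, `CCOC(=O)c1cc(NC(=O)c2cnc(Cl)nc2C(F)(F)F)cc(C(F)(F)F)c1`: in this assay compound 2 gives 280 nM.
Compound 3, `CCCCCCOC(=O)c1cc(NC(=O)c2cnc(Cl)nc2C(F)(F)F)cc(C(F)(F)F)c1`: in this assay compound 3 gives 620 nM.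

Compound 3 has the higher of the two numbers shown; its nearest neighbour is compound 2, reached by a 2.2-fold higher number from compound 2 to compound 3 (0.35 log units; beyond the scatter), a modest step toward a weaker inhibitor. Compound 4, `CCCCCCCCOC(=O)c1cc(NC(=O)c2cnc(Cl)nc2C(F)(F)F)cc(C(F)(F)F)c1`, differs from compound 3 only by ethyl in place of hydrogen on a saturated chain carbon, six bonds along the chain from an oxygen next to a carbonyl group. For the measured compounds named here, the steps of an at least 35-fold lower number from compound 1 to compound 2 (1.55 log units; beyond the scatter) and an at least 16-fold lower number from compound 1 to compound 3 (1.20 log units; beyond the scatter) replace the amide by an ester and do not bear on the chain length; only the step from compound 2 to compound 3 does, and it was modest. A further modest rise is therefore expected, a 1.8-fold higher number from compound 3 to compound 4 (0.25 log units; within the scatter). Compound 4 is estimated at 1100 nM, with a range from 400 nM to 3500 nM.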

Compound 4, half-maximal inhibitory concentration: 1800 nM
Compound 4: middle estimate off by 1.6-fold (0.21 log units), on the low side; measured number inside the range.
By their numbers in this assay, from the lowest: compound 2; then compound 3; then compound 4. At a limit, above all of these: compound 1.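

Making the ester chain longer keeps raising the number in this assay: going from the hexyl to the octyl ester gives a 2.9-fold higher number from compound 3 to compound 4 (0.46 log units; beyond the scatter), and across the three esters shown the rise adds up to a 6.4-fold higher number from compound 2 to compound 4 (0.81 log units; beyond the scatter), with none going against this trend. Even so, the octyl ester remains the stronger inhibitor when set against the butyl amide, with an at least 5.5-fold lower number from compound 1 to compound 4 (0.74 log units; beyond the scatter). That step rests on compound 1, whose value is a limit of the assay and not a number: the limit of > 10000 nM in this assay, at which 1 of the 4 values shown sits.

From the compounds shown here alone, whether a chain longer than octyl, a branched chain, or a chain ending in an amine or a carboxylic acid would continue this rise remains open. So does whether a methyl ester would give a lower number than compound 2.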